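This account rests on a few compounds, and the source may have more. Where it says the series, first, only, none or still open, it means among the compounds named here.

Compound 3 `O=c1[nH]c(=O)n(CCC(CO)CO)cc1C#CCc1ccccc1` carries the shared core with a free diol chain and a benzyl group on its alkyne. In a functional assay on MCF7 cells (Homo sapiens) for antiproliferative activity, read by MTT assay, with a stated time of 72 h (a higher number here means a weaker inhibitor, a lower number a stronger inhibitor), compound 3 gives only a limit, > 100000 nM, not a number. Two related compounds carry a benzoyl group and acetylated hydroxyls on the same core: compound 1 `CC(=O)OCC(CCn1cc(C#Cc2ccc(Br)cc2)c(=O)n(C(=O)c2ccccc2)c1=O)COC(C)=O`, with a bromophenyl on the alkyne, gives 28900 nM in this assay, and compound 2 `CCCCCc1ccc(C#Cc2cn(CCC(COC(C)=O)COC(C)=O)c(=O)n(C(=O)c3ccccc3)c2=O)cc1`, with a pentylphenyl there, gives 100 nM. Going by the values given here, the only measured single-point step, a 290-fold lower number from compound 1 to compound 2 (2.46 log units; beyond the scatter), shows that extending the far end of the alkyne with a long alkyl chain goes together with a much lower number.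

Compound 4 `CCCCCCCCC#Cc1cn(CCC(CO)CO)c(=O)[nH]c1=O` differs from compound 3 by heptyl in place of phenyl on a saturated chain carbon bound to a triple-bonded carbon. This is not the same change: the measured step added a chain to an aromatic ring, whereas here the ring itself is replaced by a chain, and compound 3 and compound 4 lack the protecting groups of compound 1 and compound 2. Even so, the direction of the measured step is the only guide, and the step of an at least 5.0-fold lower number from compound 3 to compound 4 (0.69 log units; beyond the scatter) is expected to move the number down from the limit. Compound 4 is therefore estimated at 20000 nM in this assay, within a range from 3000 nM to 150000 nM.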

Compound 4, half-maximal inhibitory concentration: 40300 nM
Compound 4: the middle estimate sits 2.0-fold (0.30 log units) below what was measured; low and high end bracket the measured number.
By their numbers in this assay, from the lowest: compound 2; then compounds 1 and 4 (each within the scatter of the next). At a limit, above all of these: compound 3.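

In this assay, the change from phenyl to heptyl on a saturated chain carbon bound to a triple-bonded carbon gives an at least 2.4-fold lower number from compound 3 to compound 4 (0.39 log units; beyond the scatter), and this step is beyond the scatter. The earlier step concerned a group on an aromatic carbon in compounds carrying benzoyl and acetyl groups, whereas this one shows that, with a free diol chain on the shared core, an open chain in place of the ring also goes with a lower number. Its size remains a minimum, as compound 3 has only a limit and not a number, and that limit is the one shown in this set of compounds: the limit of > 100000 nM in this assay, at which 1 of the 4 values shown sits.

As far as these compounds go, it remains open whether a longer chain than the octyl group of compound 4, or an amine or a carboxylic acid at the end of that chain, would move the number further. It is also open how far the benzoyl group and acetylated hydroxyls would shift the number of compound 4, as no compound shown pairs them with this chain.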